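Hydroxy for methyl on the amide side chain

This account rests on a few compounds, and the source may have more. Where it says the series, first, only, none or still open, it means among the compounds named here.

Compound 2 `CCCNC(=O)c1c(NO)cc(-c2ccccc2)oc1=O` stands at a limit in an ADME assay on Huh-7 cells (Homo sapiens) for cytotoxicity, read by a luciferase reporter and WST assay, with a stated time of 3 days; a lower number here means that less compound is tolerated, a higher number that more compound is tolerated: compound 2 gives > 20000 nM, which is a limit of the assay and not a number. Compound 1 `O=C(Nc1ccc(Cl)cc1)c1c(NO)cc(-c2ccccc2)oc1=O` likewise gives only a limit, > 20000 nM. The step that the two limits leave unreadable from compound 1 to compound 2 is therefore unreadable, and the limit of > 20000 nM in this assay, at which 2 of the 2 values shown sit, is all the series shows so far. Compound 3 `O=C(NCCO)c1c(NO)cc(-c2ccccc2)oc1=O` differs from compound 2 by hydroxy in place of methyl on a saturated chain carbon, two bonds along the chain from an amide-type nitrogen. Going by the values given here, no measured step bears on this change, and no shift beyond the scatter can be read from the series. Compound 3 is therefore expected at 30000 nM, within 15000 nM to 60000 nM. The expected step that the limit leaves unreadable from compound 2 to compound 3 most likely again ends as a limit.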

Compound 3, half-maximal cytotoxic concentration: > 20000 nM
Compound 3 ended at the assay's limit; the forecaster's own chance of this, stated with the estimate: 85%; the middle value is on the limit's open side.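

Compound 1, compound 2 and compound 3 each stand only at a limit of the assay, so no step among them can be read: the limit of > 20000 nM in this assay, at which 3 of the 3 values shown sit.
From the compounds shown here alone, the concentration at which any of these three compounds reaches half-maximal cytotoxicity stays open.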